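This account rests on a few compounds, and the source may have more. Where it says the series, first, only, none or still open, it means among the compounds named here.

Compound 2 `FC(F)(F)c1ccccc1-c1nc(NCc2ccc(Cl)cc2)c2ccccc2n1` gives 4800 nM in an assay on a protein complex for inhibition of ubiquitin carboxyl-terminal hydrolase 1/WD repeat-containing protein 48 (Homo sapiens), read by fluorescence; a lower number here means a stronger inhibitor, a higher number a weaker inhibitor; compound 1 `Cc1ccc(CNc2nc(-c3ccccc3C(F)(F)F)nc3ccccc23)s1` gives 5100 nM, within the scatter of it (a 1.1-fold lower number from compound 1 to compound 2 (0.03 log units; within the scatter)), and compound 3 `FC(F)(F)c1ccccc1-c1nc(NCc2ccc(Cl)c(Cl)c2)c2ccccc2n1` gives 10400 nM, beyond it. Compound 4 `FC(F)(F)c1ccccc1-c1nc(NCc2ccc(-c3ccc(Cl)cc3)cc2)c2ccccc2n1` differs from compound 2 by 4-chlorophenyl in place of chloro on an aromatic carbon. Of the measured steps, a 2.2-fold higher number from compound 2 to compound 3 (0.34 log units; beyond the scatter) and a 2.0-fold higher number from compound 1 to compound 3 (0.31 log units; beyond the scatter) show that adding chloro in place of hydrogen costs modestly, whereas exchanging the whole ring in a 1.1-fold lower number from compound 1 to compound 2 (0.03 log units; within the scatter) changed nothing. None of them tests a group as large as 4-chlorophenyl, so the guidance is thin. The expected step in this assay is therefore a 1.4-fold higher number from compound 2 to compound 4 (0.13 log units; within the scatter), small or a modest rise at most. Compound 4 is estimated at 6500 nM, with a range from 1500 nM to 28000 nM.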

Compound 4, half-maximal inhibitory concentration: 3600 nM
Beside the measured number, compound 4's estimate is 1.8-fold (0.26 log units) above it, and the stated range covers the measured number.
By their numbers in this assay, from the lowest: compounds 4, 2 and 1 (each within the scatter of the next); then compound 3.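

In this assay, the step with 4-chlorophenyl in place of chloro, a 1.3-fold lower number from compound 2 to compound 4 (0.12 log units; within the scatter), is within the scatter, although the group grows from one heavy atom to seven and brings a six-membered aromatic ring. This carbon therefore accepts a much larger group without a measurable change, which the earlier, smaller changes could not show. No evidence is available to explain this result. From the compounds shown here alone, it remains open whether the chlorine on the added ring matters, and whether an amine, a carboxylic acid or a longer chain at this carbon would leave the number unchanged.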